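The source may hold more compounds than are shown below. What is called first, only, known or untested is meant among the compounds shown, and "the series" means these compounds.

Measured so far:
- compound 2, `O=C(NCc1ccc(S(=O)(=O)N2CCCCC2)cc1)c1cc2cnccc2s1`: 150 nM
- compound 1, `O=C(NCc1ccc(S(=O)(=O)c2ccccc2)cc1)c1ccc2ncncc2c1`: 1900 nM
- compound 3, `CC(NC(=O)c1cc2cnccc2[nH]1)c1ccc(S(=O)(=O)N2CCCCC2)cc1`: > 10000 nM (a limit, not a number)

In an assay for inhibition of Nicotinamide phosphoribosyltransferase (Homo sapiens), read by mass spectrometry, with stated times of 15 min and 30 min (a lower number here means a stronger inhibitor, a higher number a weaker inhibitor), compound 2 gives 150 nM, the lowest of the two numbers shown. Compound 1, which carries a different sulfonyl group and a different bicyclic amide part, gives 1900 nM in this assay, a number well above that of compound 2 and beyond the usual scatter. For compound 3 the result in this assay is a limit rather than a number: the limit of > 10000 nM in this assay, at which 1 of the 3 values shown sits. Because no two of the measured compounds differ in just one place, no measured step can be read off from them.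

Compound 4, `O=C(NCc1ccc(S(=O)(=O)N2CCCCC2)cc1)c1cc2cccnc2s1`, differs from compound 2 by a group of 9 heavy atoms (7 carbon, 1 nitrogen, 1 sulfur; one five-membered aromatic ring with 1 hetero atom, one six-membered aromatic ring with 1 hetero atom) in place of a group of 9 heavy atoms (7 carbon, 1 nitrogen, 1 sulfur; one five-membered aromatic ring with 1 hetero atom, one six-membered aromatic ring with 1 hetero atom), on a carbonyl carbon; the two have the same atoms, joined differently. Among the compounds with values here, no measured pair isolates such a rearrangement, so its size is uncertain; a modest weakening, or none beyond the scatter, is expected. The expected step is a 2.7-fold higher number from compound 2 to compound 4 (0.43 log units; beyond the scatter). Compound 4 is therefore estimated to give 400 nM in this assay, with a likely range from 100 nM to 2000 nM.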

Compound 4, half-maximal inhibitory concentration: 8 nM
Compound 4: the middle estimate sits 50-fold (1.70 log units) above what was measured; the measured number lies below the stated range.
By their numbers in this assay, from the lowest: compound 4; then compound 2; then compound 1. At a limit, above all of these: compound 3.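

On a carbonyl carbon whose other neighbours are an amide-type nitrogen, joining the same atoms differently gives a 19-fold lower number from compound 2 to compound 4 (1.27 log units; beyond the scatter) in this assay. This shows that the number at this position depends strongly on how the group is joined, and not only on which atoms it holds: the group that leaves and the group that enters each have 9 heavy atoms (7 carbon, 1 nitrogen, 1 sulfur), one five-membered aromatic ring with 1 hetero atom, and one six-membered aromatic ring with 1 hetero atom, with the same counts of hydrogen-bond donors and acceptors and no net charge. Nothing measured among these compounds speaks to the reason for a step of this size.

The compounds shown leave open whether the entering group keeps its low number when the sulfonyl group of compound 4 is replaced by another one, such as a methylsulfonyl group. They also leave open how far this position tolerates additions to the entering group, such as a fluorine, a methyl or an amine, and whether any of these would hold the number that compound 4 gives.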